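The source may report more compounds than this note shows. Statements on the series, on what has been measured and on what is new or still open speak of the compounds shown alone.

Working notes on the series. Going by the values given here, in a functional assay on A549 cells (Homo sapiens) for cytotoxicity, read by WST assay, with a stated time of 48 h (on this read-out lower numbers stand for stronger inhibition and higher numbers for weaker inhibition), compound 3 (`N#C/C(=C\c1c[nH]c2cc(F)ccc12)C(=O)c1c[nH]c2ccccc12`) gives 22700 nM, the highest number of the three measured so far. Compound 1 (`COc1ccc2c(/C=C(\C#N)C(=O)c3c[nH]c4cc(F)ccc34)c[nH]c2c1`) gives 5500 nM and compound 2 (`COc1ccc2c(/C=C(\C#N)C(=O)c3c[nH]c4cc(OC)ccc34)c[nH]c2c1`) gives 1700 nM, both lower and both separated from compound 3 by more than the usual scatter.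

The next comparison is compound 4 (`COc1ccc2c(/C=C(\C#N)C(=O)c3c[nH]c4ccccc34)c[nH]c2c1`), not yet measured in this assay. The change is methoxy in place of fluoro on an aromatic carbon, on a ring meta to a fused ring and para to a fused ring.

Among the compounds with values here, one measured step bears on this: a 3.2-fold lower number from compound 1 to compound 2 (0.51 log units; beyond the scatter). It is the same exchange and a modest one, beyond the scatter. The match is incomplete, as that exchange sits at a different carbon of the shared core, and compound 1 already carries a methoxy group whereas compound 3 carries none. With a single precedent, the direction is more secure than the size.

A modest lowering of similar size is therefore expected, and the estimated change is a 3.2-fold lower number from compound 3 to compound 4 (0.51 log units; beyond the scatter). For compound 4 the estimate is 7000 nM, with an expected range of 2500 nM to 18000 nM.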

Compound 4, half-maximal inhibitory concentration: 5800 nM
The estimate for compound 4 lay 1.2-fold (0.08 log units) above the measured number; the range from low to high includes it.
By their numbers in this assay, from the lowest: compound 2; then compounds 1 and 4 (each within the scatter of the next); then compound 3.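

The exchange of fluoro for methoxy, a 3.9-fold lower number from compound 3 to compound 4 (0.59 log units; beyond the scatter), now has a second instance at a different carbon, so its lowering of the number is no longer tied to a single place on the shared core: the same change on two cores in this assay, a 3.2-fold lower number (0.51 log units; beyond the scatter) from compound 1 to compound 2 and a 3.9-fold lower number (0.59 log units; beyond the scatter) from compound 3 to compound 4, 1.2-fold (0.08 log units) apart, within the scatter of two such steps

Going by these compounds alone, the new compound also supplies the hydrogen comparison that the earlier compounds lacked. At the carbon changed between compound 1 and compound 2, hydrogen and fluoro are not told apart, a 1.1-fold higher number from compound 1 to compound 4 (0.02 log units; within the scatter), whereas taking methoxy away from that carbon gives a 3.4-fold higher number from compound 2 to compound 4 (0.53 log units; beyond the scatter). The step at that carbon therefore reads as a gain with methoxy present, not as a gain from fluoro leaving.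

Still open, on these data alone, is how hydrogen would compare with fluoro and methoxy at the carbon that carries fluoro in compound 3, and whether the two methoxy steps would hold on other cores. As far as these compounds go, it is also open whether a hydroxyl, an amine or a longer chain such as ethoxy at either carbon would lower the number further in this assay or reverse the trend.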